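Swapping an acetamido for a hydroxy on a sugar ring

The compounds below may be only part of what the source reports. "The series", "measured", "known", "first", "only" and "open" are said of these compounds alone.

Compound 1 `CO[C@@H]1O[C@H](CN([C@@H](C(=O)O)C(C)C)S(=O)(=O)c2ccc(-c3ccccc3)cc2)[C@@H](O)[C@H](O)[C@H]1NC(C)=O` gives 890 nM in an assay on isolated protein for inhibition of matrix metalloproteinase-9 (Homo sapiens), read by fluorescence, with stated times of 3 h, 10 s and 15 min; a lower number here means a stronger inhibitor, a higher number a weaker inhibitor. Compound 2 `CC(=O)N[C@@H]1[C@@H](O)[C@H](O)[C@@H](CO)O[C@H]1NC(=S)NCCN([C@@H](C(=O)O)C(C)C)S(=O)(=O)c1ccc(-c2ccccc2)cc1` gives 5400 nM, and compound 3 `CC(C)[C@H](C(=O)O)N(CCNC(=S)N[C@@H]1O[C@H](CO)[C@@H](O)[C@H](O)[C@H]1O)S(=O)(=O)c1ccc(-c2ccccc2)cc1` gives 1120 nM. The change from compound 2 to compound 3 is hydroxy in place of acetamido on a saturated ring carbon and brought a 4.8-fold lower number from compound 2 to compound 3 (0.68 log units; beyond the scatter). The difference between the cores of compound 1 and compound 2 is not broken down here. Compound 4 `CO[C@@H]1O[C@H](CN([C@@H](C(=O)O)C(C)C)S(=O)(=O)c2ccc(-c3ccccc3)cc2)[C@@H](O)[C@H](O)[C@H]1O` is still unmeasured; it differs from compound 1 by hydroxy in place of acetamido on a saturated ring carbon, the same kind of change, seen twice among these compounds, though the ring carbon here sits next to the ring atom that bears a methoxy group and three ring bonds from the ring atom that bears a large group. Set beside a 4.8-fold lower number from compound 2 to compound 3 (0.68 log units; beyond the scatter), the step expected from compound 1 to compound 4 is a 2.5-fold lower number from compound 1 to compound 4 (0.41 log units; beyond the scatter), which rests on compound 3 alone. Compound 4 is therefore estimated at 350 nM, between 120 nM and 900 nM.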

Compound 4, half-maximal inhibitory concentration: 2200 nM
Compound 4: middle estimate off by 6.3-fold (0.80 log units), on the low side, and the stated range ends below it.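

In this assay, putting hydroxy in place of acetamido gave a 2.5-fold higher number from compound 1 to compound 4 (0.39 log units; beyond the scatter), the opposite direction from the earlier step on the other core. The effect of this change therefore did not carry from one core to the other: the same change on two cores in this assay, a 4.8-fold lower number (0.68 log units; beyond the scatter) from compound 2 to compound 3 and a 2.5-fold higher number (0.39 log units; beyond the scatter) from compound 1 to compound 4, 12-fold (1.08 log units) apart, beyond the scatter of two such steps. This does not show why the two results part ways, and two pairs cannot predict the change on any further core in this series.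

On these data alone, it remains open which of the differences between the two cores separates these results. As far as these compounds go, it is also open whether an amine on the same ring carbon would follow the pattern of compound 1 and compound 4 or that of compound 2 and compound 3.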